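The compounds below may be only part of what the source reports. "The series", "measured", "known", "first", "only" and "open" are said of these compounds alone.

Measured compounds in a functional assay on ACHN cells (Homo sapiens) for inhibition, read by sulforhodamine B assay, with a stated time of 48 h; a higher number here means that more compound is tolerated, a lower number that less compound is tolerated:
- compound 1 `O=C(Nc1cccc(-n2cc(-c3ccncc3)c(-c3ccc(Cl)c(O)c3)n2)c1)Nc1ccc(Cl)c(Cl)c1`: > 32500 nM
- compound 2 `COc1cc(-c2nn(-c3cccc(NC(=O)Nc4ccc(Cl)c(C(F)(F)F)c4)c3)cc2-c2ccncc2)ccc1Cl`: > 32500 nM

Compound 2 stands at a limit of this assay, not at a number: its value > 32500 nM is the concentration up to which testing went. Compound 1 likewise reaches only a limit, > 32500 nM. Among the compounds with values here, no step between the two can be computed, since they differ in more than one place; both sit at the same limit, (the limit of > 32500 nM in this assay, at which 2 of the 2 values shown sit), so the series so far shows no measured potency in this assay.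

Compound 3 `O=C(Nc1cccc(-n2cc(-c3ccncc3)c(-c3ccc(Cl)c(O)c3)n2)c1)Nc1ccc(Cl)c(C(F)(F)F)c1` is the next member to be tested. It differs from compound 2 by hydrogen in place of methyl on an oxygen on an aromatic ring. Compound 1 already carries the hydroxy form of that ring and also stops at the limit, so the change itself has not produced a number anywhere in the set.

The expectation for the step from compound 2 to compound 3 is therefore none beyond the scatter, with a step that the limit leaves unreadable from compound 2 to compound 3. Compound 3 is expected to come out around 40000 nM, within 15000 nM to 110000 nM, most probably again as a limit rather than a number.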

Compound 3, concentration lethal to 50% of the cells: > 32500 nM
Compound 3 gave a limit, no number; the forecaster's own chance of this, stated with the estimate: 80%; the middle value lies beyond the limit too.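

In this assay, within the data shown here, compound 3 gives only a limit, > 32500 nM, so no step to it from compound 1 or compound 2 can be read. All three compounds stand at the same limit: the limit of > 32500 nM in this assay, at which 3 of the 3 values shown sit.

The compounds shown leave open whether methoxy to hydroxy, or chloro to trifluoromethyl, makes any difference to the lethal concentration in these cells.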